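A sulfamoylphenyl isomer of compound 2 awaits measurement

The compounds below may be only part of what the source reports. "The series", "measured", "known", "first", "only" and "open" are said of these compounds alone.

Within the data shown here, compound 2, `NS(=O)(=O)c1ccc(Nc2nccc(-c3nn(Cc4cccnc4)c4ccccc34)n2)cc1`, and compound 1, `CCn1nc(-c2ccnc(Nc3cccc(S(N)(=O)=O)c3)n2)c2ccccc21`, share a core but differ in two places, so no single step joins them. In a functional assay on HCT-116 cells (Homo sapiens) for antiproliferative activity, read by MTT assay, with a stated time of 72 h (on this read-out higher numbers stand for weaker inhibition of growth and lower numbers for stronger inhibition of growth), compound 2 gives 5130 nM. In this assay compound 1 gives 9010 nM; these two values lie within the scatter of each other, and compound 2 merely holds the lower of the two numbers on hand. Compound 3, `NS(=O)(=O)c1cccc(Nc2nccc(-c3nn(Cc4cccnc4)c4ccccc34)n2)c1`, has not yet been measured. It keeps everything of compound 2 except one change: 3-sulfamoylphenyl in place of 4-sulfamoylphenyl on a nitrogen on an aromatic ring. Among the measured compounds shown here, with no measured step of this kind to lean on, and with compound 1 and compound 2 lying within the scatter of each other, no shift beyond the scatter is expected in this assay for compound 3, in either direction. The step of a 1.4-fold higher number from compound 2 to compound 3 (0.13 log units; within the scatter) is therefore estimated to be small. Compound 3 is expected at 7000 nM, within a range from 2500 nM to 20000 nM.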

Compound 3, concentration for 50% growth inhibition: 8280 nM
For compound 3 the middle estimate is 1.2-fold (0.07 log units) below the measured one; the range from low to high includes it.
By their numbers in this assay, from the lowest: compounds 2, 3 and 1 (each within the scatter of the next).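

In this assay, among these compounds, the exchange of 4-sulfamoylphenyl for 3-sulfamoylphenyl on a nitrogen on an aromatic ring is the first single-place step at this position, and it gives a 1.6-fold higher number from compound 2 to compound 3 (0.21 log units; within the scatter). With 3-sulfamoylphenyl held in place, pyridin-3-yl in place of methyl on a saturated chain carbon bound to an aromatic nitrogen gives a 1.1-fold lower number from compound 1 to compound 3 (0.04 log units; within the scatter), so the two differences between compound 1 and compound 2 can now be read one at a time, and neither step leaves the scatter. No measurement at hand bears on why these steps are this small.

The three compounds therefore fall in no order. As far as these compounds go, whether a carboxylic acid or an amine in place of the sulfamoyl group, or a longer chain on the aromatic nitrogen, would move growth inhibition beyond the scatter remains open.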